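The source may report more compounds than this note shows. Statements on the series, on what has been measured and on what is new or still open speak of the compounds shown alone.

Measured in a functional assay on HeLa cells (Homo sapiens) for antiproliferative activity, read by CCK-8 assay, with a stated time of 72 h; a higher number here means a weaker inhibitor, a lower number a stronger inhibitor:
compound 1 `CCc1ccc(SCc2ccc(C(=O)Nc3ccccc3N)cc2)cc1`: 3800 nM
compound 2 `Cc1ccc(SCc2ccc(C(=O)Nc3ccccc3N)cc2)cc1`: 4250 nM

Compound 2 stands level with compound 1 within the scatter, and these two values are all the series offers so far. Next is compound 3 `Nc1ccccc1NC(=O)c1ccc(CSCCc2ccccc2)cc1`, with phenethyl in place of 4-methylphenyl on a sulfur. Going by the values given here, one measured step bears on this, and only loosely: a 1.1-fold higher number from compound 1 to compound 2 (0.05 log units; within the scatter). That step, hydrogen in place of methyl on a saturated chain carbon bound to an aromatic carbon, falls inside the group that now leaves. Among the compounds with values here, no measured step replaces that whole group, so the expectation stays wide. The expected step is a 1.1-fold higher number from compound 2 to compound 3 (0.02 log units; within the scatter), meaning no shift beyond the scatter in this assay and no favoured direction. Compound 3 is estimated at 4500 nM, with an expected range of 1500 nM to 12000 nM.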

Compound 3, half-maximal inhibitory concentration: 6430 nM
For compound 3 the middle estimate is 1.4-fold (0.15 log units) below the measured one, within the range that was stated.
By their numbers in this assay, from the lowest: compounds 1, 2 and 3 (each within the scatter of the next).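

Compounds 1 and 2 differ only inside the aryl group on the sulfur, whereas compound 3 replaces that whole group, and this assay records a 1.5-fold higher number from compound 2 to compound 3 (0.18 log units; within the scatter). Set against the 4-ethylphenyl group of compound 1, the same replacement gives a 1.7-fold higher number from compound 1 to compound 3 (0.23 log units; within the scatter), so the sulfur carries phenethyl, 4-methylphenyl or 4-ethylphenyl with no separation beyond the scatter in this assay. No measured evidence accompanies these compounds to explain this result.

On these data alone, all three compounds keep an all-carbon group with one aromatic ring on the sulfur, so it remains open whether an amine or a carboxylic acid at this place, or a longer chain, would shift the number beyond the scatter. As far as these compounds go, the shared core is the same in all three, so its contribution also remains open.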